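The source may report more compounds than this note shows. Statements on the series, on what has been measured and on what is new or still open speak of the compounds shown alone.

Compound 1 `Oc1ccc(-c2cc(-c3cccc(O)c3)nc(-c3cccc(O)c3)c2)cc1` — in a functional assay on HCT-15 cells (Homo sapiens) for cytotoxicity, read by CCK-8 assay, with a stated time of 4 days (on this read-out higher numbers stand for weaker inhibition and lower numbers for stronger inhibition), compound 1 gives 3810 nM.
Compound 2 `Oc1cccc(-c2cc(-c3ccccc3O)cc(-c3cccc(O)c3)n2)c1` — in this assay compound 2 gives 5150 nM.

Compound 2 stands at the higher of the two numbers shown, and the one step measured so far, a 1.4-fold higher number from compound 1 to compound 2 (0.13 log units; within the scatter), separates it from compound 1. Compound 3 `Oc1cccc(-c2cc(-c3cccc(O)c3)nc(-c3cccc(O)c3)c2)c1` is not yet measured; it differs from compound 2 by 3-hydroxyphenyl in place of 2-hydroxyphenyl on an aromatic carbon. Among the measured compounds shown here, the only measured step touching this position is a 1.4-fold higher number from compound 1 to compound 2 (0.13 log units; within the scatter), which stayed within the scatter, so for this assay no step beyond the scatter is expected in either direction. Compound 3 is therefore estimated at 4200 nM, with a range of 1800 nM to 9500 nM. That estimate means an expected step of a 1.2-fold lower number from compound 2 to compound 3 (0.09 log units; within the scatter).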

Compound 3, half-maximal inhibitory concentration: 3950 nM
Compound 3: middle estimate off by 1.1-fold (0.03 log units), on the high side; low and high end bracket the measured number.
By their numbers in this assay, from the lowest: compounds 1, 3 and 2 (each within the scatter of the next).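

On the aromatic carbon opposite the ring nitrogen, all three hydroxyphenyl isomers can now be compared in this assay and the new 3-hydroxyphenyl group adds two steps. Against 2-hydroxyphenyl it gives a 1.3-fold lower number from compound 2 to compound 3 (0.12 log units; within the scatter) and against 4-hydroxyphenyl it gives a 1.0-fold higher number from compound 1 to compound 3 (0.02 log units; within the scatter) so moving the hydroxyl around this ring gives no step beyond the scatter in these three compounds. No evidence is available to explain this result.

As far as these compounds go, whether an amine or a carboxylic acid in place of the hydroxyl would shift the number remains open. From the compounds shown here alone, the contribution of the two 3-hydroxyphenyl groups also remains open.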